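Oxadiazole aryl substituent: pyridin-3-yl to pyridin-4-yl

The source may hold more compounds than are shown below. What is called first, only, known or untested is meant among the compounds shown, and "the series" means these compounds.

Among the measured compounds shown here, the series so far holds compound 1 `O=C1NC(=O)/C(=C/c2ccc(OCCSc3nnc(-c4ccccc4)o3)cc2)S1` and compound 2 `O=C1NC(=O)/C(=C/c2ccc(OCCSc3nnc(-c4cccnc4)o3)cc2)S1`. In a functional assay on the whole organism (plasma, strain Wistar) with Rattus norvegicus as the target, with a stated time of 15 days, at a dose of 3 mg/kg by the oral route (a higher number here means a stronger effect of the compound at the dose given, a lower number a weaker effect), compound 1 gives 11.6%, and compound 2 gives 24.4%, the higher of the two numbers; the step of a number 12.8 percentage points higher from compound 1 to compound 2 (beyond the scatter) is the only one measured. Compound 3 `O=C1NC(=O)/C(=C/c2ccc(OCCSc3nnc(-c4ccncc4)o3)cc2)S1` is not yet measured. Its difference from compound 2 is pyridin-4-yl in place of pyridin-3-yl on an aromatic carbon. For the measured compounds named here, no measured step moves the ring nitrogen within the pyridine; the step from compound 1 to compound 2 only shows that a pyridin-3-yl, against phenyl, gave a modest gain in this assay, so it bears on the new change indirectly at best. With the same atoms joined differently, the expectation is a step of about a number 0.4 percentage points lower from compound 2 to compound 3 (within the scatter), that is none beyond the scatter. The estimate for compound 3 in this assay is therefore 24%, expected to fall between 8% and 40%.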

Compound 3, a percentage reported as activity, at one dose (the size of the read-out at that dose, not a potency): 23.5%
Compound 3: the middle estimate sits 0.5 percentage points above what was measured; the measured number falls inside the stated range.
By their numbers in this assay, from the lowest: compound 1; then compounds 3 and 2 (each within the scatter of the next).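

In this assay, pyridin-4-yl in place of pyridin-3-yl on this aromatic carbon gives a number 0.9 percentage points lower from compound 2 to compound 3 (within the scatter), so the two pyridines cannot be told apart in this read-out. The gain over phenyl also recurs with the second pyridine, a number 11.9 percentage points higher from compound 1 to compound 3 (beyond the scatter), which means that at this position it is not confined to pyridin-3-yl and, across these compounds, does not depend on which of the two pyridine attachments is present. Nothing at hand explains the gain over phenyl or the match between the two pyridines.

Still open, going by these compounds, is whether pyridin-2-yl, or a phenyl carrying an amine or a carboxylic acid, would reach the level of the two pyridines at this carbon. The compounds shown also leave open whether compound 2 and compound 3 would stay level at other doses.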